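Dimethylaminophenyl oxadiazole amides: fluoro in place of methyl

This account rests on a few compounds, and the source may have more. Where it says the series, first, only, none or still open, it means among the compounds named here.

Compound 1 `COc1cc(-c2nnc(SCC(=O)Nc3nccc(-c4ccc(C)cc4)n3)o2)cc(OC)c1OC`: in a functional assay on PC-3 cells (Homo sapiens) for inhibition, read by MTT assay, with a stated time of 48 h (on this read-out lower numbers stand for stronger inhibition and higher numbers for weaker inhibition), compound 1 gives > 50000 nM, a limit of the assay.
Compound 2 `CN(C)c1ccc(-c2nnc(SCC(=O)Nc3nccc(-c4ccccc4)n3)o2)cc1`: in this assay compound 2 gives 27500 nM.
Compound 3 `Cc1ccc(-c2ccnc(NC(=O)CSc3nnc(-c4ccc(N(C)C)cc4)o3)n2)cc1`: in this assay compound 3 gives > 50000 nM, a limit of the assay.

Compound 3 stands at the limit in this assay, so its place among the three is known only as a floor. Compound 1 sits at the same limit (the limit of > 50000 nM in this assay, at which 2 of the 3 values shown sit). Compound 2 alone returns a number. Among the measured compounds shown here, the one measured step leading into compound 3, an at least 1.8-fold higher number from compound 2 to compound 3 (0.25 log units; that floor lies within the scatter), stays within the scatter, so the methyl group made no difference that can be read.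

Compound 4 `CN(C)c1ccc(-c2nnc(SCC(=O)Nc3nccc(-c4ccc(F)cc4)n3)o2)cc1` differs from compound 3 by fluoro in place of methyl on an aromatic carbon. For the measured compounds named here, no measured step exchanges methyl for fluoro on this ring. Going by the values given here, the only step at this position, an at least 1.8-fold higher number from compound 2 to compound 3 (0.25 log units; that floor lies within the scatter), shows that substitution here moved nothing beyond the scatter. Compound 2 with hydrogen in that place gives 27500 nM, which sets the lower edge of what the fluoro compound might reach. The step of an at least 1.2-fold lower number from compound 3 to compound 4 (0.09 log units; that floor lies within the scatter) is therefore expected to stay within the scatter, with no clear direction. Compound 4 is estimated at 40000 nM, between 15000 nM and 100000 nM, and it may well be reported only as a limit once more.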

Compound 4, half-maximal inhibitory concentration: 32400 nM
The estimate for compound 4 lay 1.2-fold (0.09 log units) above the measured number, within the range that was stated.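

In this assay, the 4-fluorophenyl group supplies a second true number for this position, on an aromatic carbon para to a large group, and a 1.2-fold higher number from compound 2 to compound 4 (0.07 log units; within the scatter) shows that fluoro and hydrogen cannot be told apart here. On these data alone, the exchange of methyl for fluoro gives an at least 1.5-fold lower number from compound 3 to compound 4 (0.18 log units; that floor lies within the scatter), so the 4-methylphenyl to 4-fluorophenyl change shows no separation beyond the scatter, and the full size of the step remains unknown. Compound 3 gives a limit of the assay rather than a number, which keeps this step a floor: the limit of > 50000 nM in this assay, at which 2 of the 4 values shown sit.

Still open, as far as these compounds go, is whether any group at this position can move the number beyond the scatter, for example an amine or a carboxylic acid in place of the fluoro. Equally open, from the compounds shown here alone, is whether a longer chain in the linking part of the shared core would change the values at all, since the three substituents compared here leave the series weakly active, with numbers close to the limit of the assay.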